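A few compounds are considered here, and "the series" means these few. Any claim that something is new, unique, unknown or untested is made for them only; others in the source may bear on it.

Measured in a functional assay on HCT-116 cells (Homo sapiens) for inhibition, read by MTT assay, with a stated time of 48 h; a higher number here means a weaker inhibitor, a lower number a stronger inhibitor:
compound 1 `COc1ccc(CN(C(=O)C(C)Br)c2cc(OC)c(OC)c(OC)c2)cc1O` - 140 nM
compound 2 `C#CC(=O)N(Cc1ccc(OC)c(O)c1)c1cc(OC)c(OC)c(OC)c1` - 310 nM
compound 3 `C/C=C/C(=O)N(Cc1cccc(O)c1)c1cc(OC)c(OC)c(OC)c1` - 6700 nM

Of these three, compound 3 has the highest number and is the weakest inhibitor, with its gaps to both of the others beyond the scatter. Compound 4 `C/C=C/C(=O)N(Cc1ccc(OC)c(O)c1)c1cc(OC)c(OC)c(OC)c1` keeps the acyl group of compound 3 and differs from it by a single change (methoxy in place of hydrogen on an aromatic carbon): methoxy in place of hydrogen on an aromatic carbon, which turns 3-hydroxyphenyl into 3-hydroxy-4-methoxyphenyl.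

Among the compounds with values here, no measured step isolates this change. Within the data shown here, the only measured step, ethynyl in place of 1-bromoethyl on a carbonyl carbon, is modest (a 2.2-fold higher number from compound 1 to compound 2 (0.35 log units; beyond the scatter)) and takes place with 3-hydroxy-4-methoxyphenyl already present. Compound 1 and compound 2 both carry that group and both lie far below compound 3, but they also differ from compound 3 on the carbonyl carbon, so their gap cannot be assigned to the methoxy alone. Even so, the modest size of that one step suggests that much of the gap may travel with the methoxy. A large step to a lower number is therefore expected in this assay, probably falling somewhat short of the full gap.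

The expected change is a 13-fold lower number from compound 3 to compound 4 (1.13 log units; beyond the scatter) ( an estimate ). For compound 4 the estimated value is 500 nM (expected range 120 nM to 2200 nM).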

Compound 4, half-maximal inhibitory concentration: 55 nM
The estimate for compound 4 lay 9.1-fold (0.96 log units) above the measured number, outside the stated range (below it).
By their numbers in this assay, from the lowest: compound 4; then compound 1; then compound 2; then compound 3.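

In this assay, methoxy in place of hydrogen on an aromatic carbon, ortho to a hydroxy group and para to a large group, gives a 120-fold lower number from compound 3 to compound 4 (2.09 log units; beyond the scatter) with prop-1-en-1-yl held on the carbonyl carbon, so this single change now stands apart from any change at the carbonyl carbon. With 3-hydroxy-4-methoxyphenyl present, the group on the carbonyl carbon still shifts the number, but less: prop-1-en-1-yl in place of ethynyl gives a 5.6-fold lower number from compound 2 to compound 4 (0.75 log units; beyond the scatter) and prop-1-en-1-yl in place of 1-bromoethyl gives a 2.5-fold lower number from compound 1 to compound 4 (0.41 log units; beyond the scatter), which makes compound 4 the strongest inhibitor of the four. Nothing at hand explains why the methoxy step is so large.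

The compounds shown leave open whether an ethoxy group, a fluorine atom or an amine on that same aromatic carbon would give a step of similar size. They also leave open whether the methoxy step would keep its size with ethynyl or 1-bromoethyl on the carbonyl carbon.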